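The source may hold more compounds than are shown below. What is called first, only, known or untested is meant among the compounds shown, and "the series" means these compounds.

Measured compounds in an assay on isolated protein for binding affinity to Gonadotropin-releasing hormone receptor (Rattus norvegicus); a lower number here means a stronger inhibitor, a higher number a weaker inhibitor:

compound 1 `Cc1cc2c(cc1Cc1ccc(C(=O)NC[C@H]3CC[C@H](C(=O)O)CC3)o1)C(C)(C)CCC2(C)C`, 3000 nM
compound 2 `CCOC(=O)[C@H]1CC[C@H](CNC(=O)c2ccc(Cc3cc4c(cc3C)C(C)(C)CCC4(C)C)o2)CC1`, 2730 nM
compound 3 `Cc1cc2c(cc1Cc1ccc(C(=O)NCC3CCC(CNCc4c(C)noc4C)CC3)o1)C(C)(C)CCC2(C)C`, 1200 nM

Compound 2 stands second highest of the three numbers in this assay. Its nearest neighbour is compound 1, with a number within the scatter of it; compound 3 sits furthest off, with a lower number beyond the scatter. For the measured compounds named here, the one step measured between compounds that differ in a single place, a 1.1-fold lower number from compound 1 to compound 2 (0.04 log units; within the scatter), shows that an ethyl in place of hydrogen on an oxygen next to a carbonyl group moves nothing.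

Compound 4 `Cc1cc2c(cc1Cc1ccc(C(=O)NCC3CCCC(CN)C3)o1)C(C)(C)CCC2(C)C` is not yet measured. It differs from compound 2 by 3-(aminomethyl)cyclohexyl in place of 4-(ethoxycarbonyl)cyclohexyl on a saturated chain carbon bound to an amide-type nitrogen. Going by the values given here, no measured step covers this change: the ester-to-acid step says only that the ethoxycarbonyl end is not what sets the number, and compound 3, which carries a substituted aminomethyl on its cyclohexyl, gives the lowest number of the three. The step of a 1.8-fold lower number from compound 2 to compound 4 (0.26 log units; within the scatter) is therefore expected to be a modest one downward, with wide uncertainty. Compound 4 is estimated at 1500 nM, range 500 nM to 4500 nM.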

Compound 4, inhibition constant: 890 nM
The estimate for compound 4 lay 1.7-fold (0.23 log units) above the measured number; measured number inside the range.
By their numbers in this assay, from the lowest: compounds 4 and 3 (each within the scatter of the next); then compounds 2 and 1 (each within the scatter of the next).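

In this assay, this position responds to the change: the exchange for 3-(aminomethyl)cyclohexyl gives a step beyond the scatter from both the ester (a 3.1-fold lower number from compound 2 to compound 4 (0.49 log units; beyond the scatter)) and the acid (a 3.4-fold lower number from compound 1 to compound 4 (0.53 log units; beyond the scatter)). The earlier exchange at the far end of the 4-substituted ring moved nothing (a 1.1-fold lower number from compound 1 to compound 2 (0.04 log units; within the scatter)), so the number at this position is not fixed by the shared core alone. No supporting measurement accounts for the difference.

Each step replaces the whole group, so the compounds shown do not separate the effect of the aminomethyl from that of its placement on the ring. Also open, on these data alone, is how an open-chain primary amine, or a longer chain ending in an amine, would compare on the same saturated chain carbon.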